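Bulkier Hydroxyalkyl Side Chain Replaces the Hydroxypropyl Group

The source may hold more compounds than are shown below. What is called first, only, known or untested is meant among the compounds shown, and "the series" means these compounds.

For the measured compounds named here, compound 2 `C[C@H](O)CNCC(=O)N1CCc2ccccc2C1C1CCCCC1` gives 0% in a functional assay on the whole organism (strain ddY) with Mus musculus as the target, in the formalin test, at a dose of 100 mg/kg by the oral route (a higher number here means more inhibition at the dose given (going by the name of the read-out), a lower number less inhibition), the lower of the two numbers known so far; compound 1 `CC[C@H](O)CNCC(=O)N1CCc2ccccc2C1C1CCCCC1` gives 27%. Going by the values given here, the single measured step, a number 27 percentage points lower from compound 1 to compound 2 (beyond the scatter), is the only one that bears on the change now considered. Compound 3 `CC(C)(C)[C@@H](CO)NCC(=O)N1CCc2ccccc2C1C1CCCCC1` is not yet measured; it differs from compound 2 by 1-(hydroxymethyl)-2,2-dimethylpropyl in place of 2-hydroxypropyl on an amine nitrogen. Because more carbon enters here than the methyl whose removal gave a number 27 percentage points lower from compound 1 to compound 2 (beyond the scatter), a rise is expected. Compound 3 is therefore estimated at 25%, with a range from 0% to 50%, an expected step of a number 25 percentage points higher from compound 2 to compound 3 (beyond the scatter).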

Compound 3, a percentage reported as inhibition, in the whole organism at one dose (the size of the read-out at that dose, not a potency): 40%
For compound 3 the middle estimate is 15 percentage points below the measured one; the measured number falls inside the stated range.
By their numbers in this assay, from the lowest: compound 2; then compound 1; then compound 3.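

In this assay the amine nitrogen accepts 1-(hydroxymethyl)-2,2-dimethylpropyl with a number 40 percentage points higher from compound 2 to compound 3 (beyond the scatter) and so carries the gain beyond what 2-hydroxybutyl gave. Replacing 2-hydroxybutyl with this group still adds, with a number 13 percentage points higher from compound 1 to compound 3 (beyond the scatter) in this step, and none of the three compounds goes against a rise with added carbon on this nitrogen.

From the compounds shown here alone, it remains open whether a plain tert-butyl group without the hydroxyl, or a cyclopentyl group bearing hydroxymethyl, would hold this level. Nothing shown bears on why these steps occur.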